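Swapping the amide aryl group on a second core

This account rests on a few compounds, and the source may have more. Where it says the series, first, only, none or still open, it means among the compounds named here.

Compound 1 `COc1ccc(C(=O)NCCCOc2cc(=O)n(CCCO)c3c2CC(CC=C(C)C)C(C)(C)C3)cc1` carries a 4-methoxyphenyl group on the amide carbonyl. In a functional assay on PANC-1 cells (Homo sapiens) for inhibition, read by MTT assay, with a stated time of 24 h, tested at 10 uM (a higher number here means more inhibition at the concentration tested (going by the name of the read-out), a lower number less inhibition), compound 1 gives 55.5%. Compound 2 `CC(C)=CCC1Cc2c(OCCCNC(=O)c3ccco3)cc(=O)n(CCCO)c2CC1(C)C` differs from it in one place, (furan-2-yl in place of 4-methoxyphenyl on a carbonyl carbon), and in this assay compound 2 gives 2.1%; the step is a number 53.4 percentage points lower from compound 1 to compound 2 (beyond the scatter). Compound 3 `COc1ccc(C(=O)NCCCOc2cc(=O)n(CCCO)c3c2CC(C/C=C(\C)CCC=C(C)C)C(C)(C)C3)cc1` differs from compound 1 in the core, (3-methylbut-2-en-1-yl in place of hydrogen on a saturated chain carbon bound to a double-bonded chain carbon). In this assay compound 3 gives 45.7%, and the step is a number 9.8 percentage points lower from compound 1 to compound 3 (within the scatter). Compound 4 `CC(C)=CCC/C(C)=C/CC1Cc2c(OCCCNC(=O)c3ccco3)cc(=O)n(CCCO)c2CC1(C)C` has not yet been measured. It stands to compound 3 as compound 2 stands to compound 1: the change is furan-2-yl in place of 4-methoxyphenyl on a carbonyl carbon, the same change at the same place, on a carbonyl carbon whose other neighbours are an amide-type nitrogen; the two cores differ as described between compound 1 and compound 3. In this assay the expected step is a number 41.7 percentage points lower from compound 3 to compound 4 (beyond the scatter), a large fall of the same kind as a number 53.4 percentage points lower from compound 1 to compound 2 (beyond the scatter), and it should bottom out near zero because compound 3 starts from 45.7%. Compound 4 is accordingly estimated at 4%, between 0% and 20%.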

Compound 4, a percentage reported as inhibition, at one concentration (the size of the read-out at that concentration, not a potency): 69.5%
Estimate against measurement, compound 4: 65.5 percentage points below; measured number above the stated range.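

In this assay, the swap to furan-2-yl from 4-methoxyphenyl on the amide carbonyl does not carry from one core to the other; on the longer-chain core the step is a number 23.8 percentage points higher from compound 3 to compound 4 (beyond the scatter), which runs opposite to the fall seen on the core of compound 1: the same change on two cores in this assay, a number 53.4 percentage points lower (beyond the scatter) from compound 1 to compound 2 and a number 23.8 percentage points higher (beyond the scatter) from compound 3 to compound 4, 77.2 percentage points apart, beyond the scatter of two such steps

Read along the other change, adding 3-methylbut-2-en-1-yl to the chain gives a number 67.4 percentage points higher from compound 2 to compound 4 (beyond the scatter), while the same addition with 4-methoxyphenyl on the carbonyl gave no step beyond the scatter: the same change on two cores in this assay, a number 9.8 percentage points lower (within the scatter) from compound 1 to compound 3 and a number 67.4 percentage points higher (beyond the scatter) from compound 2 to compound 4, 77.2 percentage points apart, beyond the scatter of two such steps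

So in these compounds the outcome of each change depends on the other, but this rests on a single set of four compounds read at one concentration, and it does not show why the two changes interact or whether the reversal extends to other amide groups.

The compounds shown leave open how an unsubstituted phenyl, a thiophen-2-yl or a pyridinyl group on the carbonyl would behave on either core. They also leave open whether a still longer chain on the core would strengthen or undo the reversal.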